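Swapping a Urea Substituent on a Cytotoxicity-Limited Nucleoside

The source may report more compounds than this note shows. Statements on the series, on what has been measured and on what is new or still open speak of the compounds shown alone.

Compound 1 `CCOC(=O)CNC(=O)NC1=CS(=O)(=O)O[C@@]12[C@@H](CO[Si](C)(C)C(C)(C)C)O[C@@H](n1cc(C)c(=O)n(C)c1=O)[C@@H]2O[Si](C)(C)C(C)(C)C` is the least tolerated of the three measured compounds: in a functional assay on MT4 cells (Homo sapiens) (a higher number here means that more compound is tolerated, a lower number that less compound is tolerated), compound 1 gives 3780 nM. Compound 3 `CC(=O)NC1=CS(=O)(=O)O[C@@]12[C@@H](CO[Si](C)(C)C(C)(C)C)O[C@@H](n1cc(C)c(=O)n(C)c1=O)[C@@H]2O[Si](C)(C)C(C)(C)C` gives 10700 nM, and compound 2 `Cc1cn([C@@H]2O[C@@H]3COC4(O)CS(=O)(=O)O[C@@]34[C@H]2O)c(=O)[nH]c1=O` gives 100000 nM. For the measured compounds named here, only one measured step touches the group that is changed here: a 2.8-fold higher number from compound 1 to compound 3 (0.45 log units; beyond the scatter).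

Compound 4 `Cc1cn([C@@H]2O[C@H](CO[Si](C)(C)C(C)(C)C)[C@@]3(OS(=O)(=O)C=C3NC(=O)NC(=O)c3ccccc3)[C@H]2O[Si](C)(C)C(C)(C)C)c(=O)n(C)c1=O` differs from compound 1 as follows: benzoyl in place of (ethoxycarbonyl)methyl on an amide-type nitrogen. Going by the values given here, no measured step tests a benzoyl at this place, so the expectation rests on the one step at the same carbonyl, which was modest. A similarly small shift, in either direction, is expected: a 1.3-fold higher number from compound 1 to compound 4 (0.12 log units; within the scatter). Compound 4 is therefore estimated at 5000 nM, with a range from 1500 nM to 20000 nM.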

Compound 4, half-maximal cytotoxic concentration: 3330 nM
Estimate against measurement, compound 4: 1.5-fold (0.18 log units) above, and the stated range covers the measured number.
By their numbers in this assay, from the lowest: compounds 4 and 1 (each within the scatter of the next); then compound 3; then compound 2.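

In this assay the step of a 1.1-fold lower number from compound 1 to compound 4 (0.06 log units; within the scatter) shows that benzoyl can take the place of (ethoxycarbonyl)methyl on this amide-type nitrogen with no change beyond the scatter. With a 3.2-fold lower number from compound 3 to compound 4 (0.51 log units; beyond the scatter) beside it, methyl on the carbonyl carbon now stands apart from two different substituted amino groups, not just one. Nothing available explains these numbers.

From the compounds shown here alone, whether a plain amine, a carboxylic acid or a longer alkyl chain on this nitrogen would stay level with compound 1 and compound 4 remains open.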